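This account rests on a few compounds, and the source may have more. Where it says the series, first, only, none or still open, it means among the compounds named here.

Compound 1 `O=C(Nc1ccc(Cl)cn1)C1CCCN(C(=O)c2cc(C(F)(F)F)cc(C(F)(F)F)c2)C1` was tested in an ADME assay on PC-3 cells (Homo sapiens) for cytotoxicity, read by WST assay, tested at 100 uM (on this read-out higher numbers stand for more inhibition at the one concentration tested (going by the name of the read-out) and lower numbers for less inhibition), where compound 1 gives 0%. Two related compounds share its core. Compound 2 `N#Cc1cccc(C(=O)N2CCCC(C(=O)Nc3ccc(Cl)cc3)C2)c1` gives 0%, and compound 3 `O=C(c1ccccc1)c1cccc(C(=O)N2CCCC(C(=O)Nc3ccc(Cl)cc3)C2)c1` gives 0%. The one measured step that joins two of these compounds, benzoyl in place of cyano on an aromatic carbon, shows no change at the digits printed from compound 2 to compound 3 (within the scatter). Compound 1 stands level with compound 2 and compound 3 at the digits reported, within the scatter of both.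

The next compound, compound 4 `O=C(Nc1ccc(Cl)nc1)C1CCCN(C(=O)c2cc(C(F)(F)F)cc(C(F)(F)F)c2)C1`, has the same atoms as compound 1, joined differently: 6-chloropyridin-3-yl in place of 5-chloropyridin-2-yl on an amide-type nitrogen. For the measured compounds named here, no measured step covers a change of this kind on the amide-type nitrogen; the only measured step concerns another part of the core and was flat. All three measured compounds sit at the same reading in this assay, so the expectation for compound 4 is a step of no size beyond the scatter, which is expressed as no change at the digits printed from compound 1 to compound 4 (within the scatter). On that basis compound 4 is estimated to give 0%, with a range from 0% to 10%, in this assay.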

Compound 4, a percentage reported as inhibition, at one concentration (the size of the read-out at that concentration, not a potency): 25%
The estimate for compound 4 lay 25 percentage points below the measured number; the measured number lies above the stated range.
By their numbers in this assay, from the lowest: compounds 1, 2 and 3 (each within the scatter of the next); then compound 4.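

Changing 5-chloropyridin-2-yl to 6-chloropyridin-3-yl on the amide-type nitrogen gives the first departure from the shared level in this assay, with a number 25 percentage points higher from compound 1 to compound 4 (beyond the scatter). The two groups have the same heavy-atom count and the same count of hydrogen-bond acceptors, and compound 1 and compound 4 contain the same atoms, so this position responds to a change in how those atoms are joined, something the flat step in another part of the core could not show. Nothing available here bears on what lies behind this step.

The compounds shown leave open whether the same exchange would give a comparable step on the nitrile-bearing and benzoyl-bearing compounds, and whether the reading at this position would move further with an amine or a carboxylic acid in place of the chlorine on the 6-chloropyridin-3-yl group. Since the read-out comes from a single concentration and is not a potency, they also leave open how the effect of compound 4 would vary with concentration.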